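A few compounds are considered here, and "the series" means these few. Any claim that something is new, unique, unknown or untested is made for them only; others in the source may bear on it.

Measured compounds:
Compound 1 `O=C1O/C(=C\Cn2cc(-c3cc(F)cc(F)c3)nn2)C(OCc2ccccc2)=C1OCc1ccccc1` gives > 100000 nM in an ADME assay on HFF cells (Homo sapiens) for cytotoxicity, read by MTT assay, with a stated time of 72 h; a higher number here means a weaker inhibitor, a lower number a stronger inhibitor.
Compound 2 `COc1ccccc1-c1cn(C[C@H](O)[C@H]2OC(=O)C(OCc3ccccc3)=C2OCc2ccccc2)nn1` gives 50 nM in this assay.
Compound 3 `O=C1O/C(=C\Cn2cc(-c3cc(C(F)(F)F)cc(C(F)(F)F)c3)nn2)C(OCc2ccccc2)=C1OCc1ccccc1` gives > 100000 nM in this assay.

The value for compound 1 is a limit of the assay, not a number. The value for compound 3 is likewise a limit. Compound 2 is therefore the only one of the three with a measured number in this assay, and it stands at the strong end of what is shown, with the other two sitting at the limit of > 100000 nM in this assay, at which 2 of the 3 values shown sit.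

The step from compound 2 to compound 4 `O=C1O[C@H]([C@@H](O)Cn2cc(-c3cc(F)cc(F)c3)nn2)C(OCc2ccccc2)=C1OCc1ccccc1` changes one group on the triazole ring: 3,5-difluorophenyl in place of 2-methoxyphenyl on an aromatic carbon. The core of compound 2 is kept unchanged. For the measured compounds named here, no step between two measured compounds is available to say how large such an aryl swap tends to be, so the expectation rests on the fact that compound 2 alone carries this core and reaches 50 nM.

The expected step from compound 2 to compound 4 is a 3.0-fold higher number from compound 2 to compound 4 (0.48 log units; beyond the scatter), a modest loss of potency in this assay. Compound 4 is estimated at 150 nM, within a range from 30 nM to 1500 nM.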

Compound 4, half-maximal inhibitory concentration: > 100000 nM
Compound 4: only a limit was reported; the forecaster's own chance of this, stated with the estimate: 10%; middle value at least 660-fold (2.82 log units) away from the limit.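

In this assay, the aryl group on this aromatic carbon of the five-membered aromatic ring with 3 nitrogen turns out to carry great weight: with the core kept, putting 3,5-difluorophenyl in place of 2-methoxyphenyl gives an at least 2000-fold higher number from compound 2 to compound 4 (3.30 log units; beyond the scatter). Compound 2, at 50 nM, therefore does not owe its number to the core alone, a point that could not be seen while it was the only compound shown with this core. Compound 4 gives > 100000 nM, which is a limit of the assay and not a number, so the step marks only the smallest size the change can have, and compound 4 joins the other compounds at that limit: the limit of > 100000 nM in this assay, at which 3 of the 4 values shown sit.

The compounds shown leave open whether the change follows from the loss of the methoxy group, the arrival of the two fluorines, or both together, as the two come in a single step. A plain phenyl ring or a phenyl ring carrying one fluorine or one ethoxy group at this place would help to pull these apart.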